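Swapping cyclohexyl for phenyl on the alkyne arm

The compounds below may be only part of what the source reports. "The series", "measured", "known", "first", "only" and "open" are said of these compounds alone.

Of the compounds shown here, three have been tested in an ADME assay on Vero cells (Chlorocebus sabaeus) for cytotoxicity, read by MTT assay; on this read-out lower numbers stand for higher toxicity in this test and higher numbers for lower toxicity in this test. Compound 1 `O=c1[nH]c(=O)n([C@@H]2O[C@H](CO)[C@@H](O)[C@H]2O)cc1C#CC1CCCCC1` carries a sugar on its core and a cyclohexyl group on a triple bond; in this assay compound 1 gives 148000 nM. Compound 2 `O=c1[nH]cc(C#CC2CCCCC2)c(=O)[nH]1` lacks the sugar but keeps the same alkyne arm, and in this assay compound 2 gives 247000 nM. Compound 3 `O=c1[nH]cc(C#CC(O)c2ccccc2)c(=O)[nH]1` also lacks the sugar and bears a hydroxylated benzylic arm; in this assay compound 3 gives 242000 nM. The numbers for compound 2 and compound 3 both fall within the usual scatter of the number for compound 1, so the three cannot be separated from one another on this read-out.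

Compound 4 `O=c1[nH]c(=O)n([C@@H]2O[C@H](CO)[C@@H](O)[C@H]2O)cc1C#Cc1ccccc1` has not been measured. It differs from compound 1 in one place: phenyl in place of cyclohexyl on a triple-bonded carbon. Going by the values given here, no measured pair in this set shares that change, so there is no direct precedent for it. Since the three measured numbers sit close together and only one point on the sugar-bearing core is known, the expectation is that the step of a 1.1-fold higher number from compound 1 to compound 4 (0.03 log units; within the scatter) stays within the scatter. Compound 4 is therefore estimated at 160000 nM, in a range from 70000 nM to 400000 nM.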

Compound 4, half-maximal cytotoxic concentration: 78400 nM
Beside the measured number, compound 4's estimate is 2.0-fold (0.31 log units) above it; the measured number falls inside the stated range.
By their numbers in this assay, from the lowest: compounds 4, 1, 3 and 2 (each within the scatter of the next, the first and the last beyond it).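

In this assay, going by these compounds alone, the earlier compounds offered no pair differing in one place, so this is the first direct reading of a change on the triple-bonded carbon. Replacing the non-aromatic cyclohexyl ring with the aromatic phenyl ring, with the same count of carbons, gives a 1.9-fold lower number from compound 1 to compound 4 (0.28 log units; within the scatter), so on this sugar-bearing core the move from 2-cyclohexylethynyl to 2-phenylethynyl stays inside the normal variation between repeated measurements. No supporting measurement accompanies this result to explain the size of the step.

The compounds shown do not reveal whether the same swap would behave alike on the core without the sugar, since they include no such matched pair. They also leave open how this read-out would respond to a different kind of arm on the triple bond, such as a straight hexyl chain, or to a phenyl ring carrying an amine or a carboxylic acid.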